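Pyrazine amides on a shared quinoline-type core: compound 3

The source may report more compounds than this note shows. Statements on the series, on what has been measured and on what is new or still open speak of the compounds shown alone.

Measured so far:
compound 1 `O=C(Nc1cccc2cccnc12)c1cccc(Br)n1` — > 10000 nM
compound 2 `Cc1cnc(C(=O)Nc2cccc3ccc(C)nc23)cn1` — > 10000 nM

Compound 2 stands at a limit. In a functional assay on PANC-1 cells (Homo sapiens) for inhibition, read by MTT assay, with a stated time of 72 h (a lower number here means a stronger inhibitor, a higher number a weaker inhibitor), compound 2 gives > 10000 nM, a limit of the assay and not a number. Compound 1 gives > 10000 nM in this assay, likewise a limit. For the measured compounds named here, both measured values sit at the limit of > 10000 nM in this assay, at which 2 of the 2 values shown sit, so no step between measured compounds exists and no size of step in this assay can be read from the data. Compound 3 `Cc1ccc2cccc(NC(=O)c3cnccn3)c2n1` differs from compound 2 by hydrogen in place of methyl on an aromatic carbon. The expected step is a step that the limit leaves unreadable from compound 2 to compound 3, none beyond the scatter. Compound 3 is expected at 20000 nM, between 8000 nM and 60000 nM, most likely reported again only as a limit.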

Compound 3, half-maximal inhibitory concentration: > 10000 nM
Compound 3: a limit, no number; the forecaster's own chance of this, stated with the estimate: 85%; the middle value does not contradict the limit.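

Compound 2 and compound 3 both sit at a limit, so no step between them can be read: the limit of > 10000 nM in this assay, at which 3 of the 3 values shown sit.

The compounds shown leave open which change on the shared core, if any, would give a measurable number in this assay.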